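This account rests on a few compounds, and the source may have more. Where it says the series, first, only, none or still open, it means among the compounds named here.

Working notes on the series. Going by the values given here, compound 2 `COc1ccc([N+](=O)[O-])cc1CSc1nc2cc(NC(=O)C(C)(C)C)ccc2n1C(C)C` gives 180 nM in an assay on isolated protein for inhibition of Gonadotropin-releasing hormone receptor (Homo sapiens) (a lower number here means a stronger inhibitor, a higher number a weaker inhibitor), the highest of the two numbers at hand; the only other measured member, compound 1 `CCCn1c(SCc2cc([N+](=O)[O-])ccc2OC)nc2cc(NC(=O)NC(C)(C)C)ccc21`, gives 18 nM, a difference beyond the scatter. Compound 3 `COc1ccc([N+](=O)[O-])cc1CSc1nc2cc(NC(=O)NC3CC3)ccc2n1C(C)C` differs from compound 2 in one place: cyclopropylamino in place of tert-butyl on a carbonyl carbon. Among the compounds with values here, no direct step between measured compounds covers this change, so the expectation for the step from compound 2 to compound 3 rests on the whole of compound 1, which carries a urea and gives 18 nM: a move to a lower number, a 4.0-fold lower number from compound 2 to compound 3 (0.60 log units; beyond the scatter), is expected. Compound 3 is estimated at 45 nM, within 12 nM to 160 nM.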

Compound 3, half-maximal inhibitory concentration: 1900 nM
Compound 3: middle estimate off by 42-fold (1.63 log units), on the low side, and the stated range ends below it.
By their numbers in this assay, from the lowest: compound 1; then compound 2; then compound 3.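

In this assay, replacing tert-butyl with cyclopropylamino on the carbonyl carbon, which turns the amide into a urea, gives an 11-fold higher number from compound 2 to compound 3 (1.02 log units; beyond the scatter) and a large loss at this position. On this core, then, a urea at this position does not in itself bring a low number, and the group on the far side of the carbonyl matters. No measurement at hand accounts for the size of this step.

Going by these compounds, it remains open whether the step follows the added nitrogen or the three-membered ring. An open-chain isopropylamino on the same carbonyl carbon would separate the two.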